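The compounds below may be only part of what the source reports. "The series", "measured", "known", "first", "only" and "open" are said of these compounds alone.

Measured in an in vitro ADME assay on microsomes from liver (Rattus norvegicus) for metabolic stability; a higher number here means faster removal of the compound, a lower number slower removal:
- Compound 1 `Cc1ccc(Cn2c(=O)[nH]c3c(N)nc(C(F)(F)F)cc32)nn1`: < 11 mL.min-1.g-1 (a limit)
- Compound 2 `Cc1cc(Cn2c(=O)[nH]c3c(N)nc(C(F)(F)F)cc32)no1`: < 9 mL.min-1.g-1 (a limit)
- Compound 3 `CN1CCN(c2ccc(Cn3c(=O)[nH]c4c(N)nc(C(F)(F)F)cc43)cn2)CC1`: 46 mL.min-1.g-1

In this assay, going by the values given here, compound 3 stands at 46 mL.min-1.g-1, the only actual number among the three results. Compound 4 `Nc1ccc(Cn2c(=O)[nH]c3c(N)nc(C(F)(F)F)cc32)cn1` carries amino in place of 4-methylpiperazin-1-yl on an aromatic carbon. Among the compounds with values here, the one measured step, a step that the two limits leave unreadable from compound 1 to compound 2, runs between two limits, and it does not involve the group that changes here. Within the data shown here, no measured step starts from compound 3, so the expectation rests on an analogy. Neither compound 1 nor compound 2 carries 4-methylpiperazin-1-yl. The analogy draws on compound 1, which sits at the limit < 11 mL.min-1.g-1. It draws equally on compound 2, which sits at the limit < 9 mL.min-1.g-1. A fall beyond the scatter is therefore expected, estimated as a 3.3-fold lower number from compound 3 to compound 4 (0.52 log units; beyond the scatter). Compound 4 is estimated at 14 mL.min-1.g-1, with an expected range of 7 mL.min-1.g-1 to 28 mL.min-1.g-1.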

Compound 4, intrinsic clearance in microsomes: < 10 mL.min-1.g-1
Compound 4 ended at the assay's limit; the forecaster's own chance of this, stated with the estimate: 40%; at least 1.4-fold (0.14 log units) between middle value and limit.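

Going by these compounds alone, replacing 4-methylpiperazin-1-yl with amino, on the aromatic carbon next to the ring nitrogen, gives the first readable step in this assay (an at least 4.6-fold lower number from compound 3 to compound 4 (0.66 log units; beyond the scatter)). Within the data shown here, the pair ties the high number of compound 3 to this one place, which the earlier compounds could not do, as they differ from compound 3 in the whole group on the saturated chain carbon. From the compounds shown here alone, compound 4 gives a limit of the assay and not a number (< 10 mL.min-1.g-1), so the full size of the step stays unknown: the limit of < 10 mL.min-1.g-1 in this assay, at which 1 of the 4 values shown sits.

The steps linking compound 4 to compound 1 and compound 2 cannot be read, as all three values are limits. Also open, going by these compounds, is where between these two groups the number changes, for instance whether dimethylamino or morpholin-4-yl at the same place stays near compound 3 or falls to a limit.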